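A few compounds are considered here, and "the series" means these few. Any claim that something is new, unique, unknown or untested is made for them only; others in the source may bear on it.

Series notes. Within the data shown here, in a functional assay for agonist activity at G protein-coupled receptor 88 (Homo sapiens), read by HTRF and cAMP accumulation (on this read-out lower numbers stand for an effect already at smaller amounts and higher numbers for an effect only at larger amounts of compound), compound 1 `CC(C)(C)[C@H](N)CN(C(=O)[C@@H]1C[C@H]1c1ccccc1)c1ccc(-c2ccccc2)cc1` gives 11 nM and compound 2 `O=C([C@@H]1C[C@H]1c1ccccc1)N(CCNCC1CCCC1)c1ccc(-c2ccccc2)cc1` gives 2.5 nM; the single measured step, a 4.4-fold lower number from compound 1 to compound 2 (0.64 log units; beyond the scatter), concerns the amine-bearing chain and not the aryl end. Compound 3 `CC(C)C[C@H](N)CN(C(=O)[C@@H]1C[C@H]1c1ccccc1)c1ccc(-c2cccs2)cc1` gives 1500 nM, the highest number of the three, well beyond the scatter from both compound 1 and compound 2. Compound 4 `CC(C)C[C@H](N)CN(C(=O)[C@@H]1C[C@H]1c1ccccc1)c1ccc(-c2cccc(C#N)c2)cc1` differs from compound 3 by 3-cyanophenyl in place of thiophen-2-yl on an aromatic carbon. Among the measured compounds shown here, no measured step touches this aryl position, so the step from compound 1 to compound 2 offers no guide to size or direction; compound 1, whose aryl end is likewise a six-membered aromatic ring of carbon only, sits low, but its chain also differs from that of compound 3. For compound 4 a lower number is expected, a 3.8-fold lower number from compound 3 to compound 4 (0.57 log units; beyond the scatter), with wide uncertainty. Compound 4 is estimated at 400 nM, range 60 nM to 3000 nM.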

Compound 4, half-maximal effective concentration: 4500 nM
Estimate against measurement, compound 4: 11-fold (1.05 log units) below, and the stated range ends below it.
By their numbers in this assay, from the lowest: compound 2; then compound 1; then compound 3; then compound 4.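

The change to 3-cyanophenyl in place of thiophen-2-yl gives a 3.0-fold higher number from compound 3 to compound 4 (0.48 log units; beyond the scatter) and so brings no gain at this aromatic carbon on the chain shared by these two compounds. With this chain, a six-membered aromatic ring of carbon only does not by itself give a low number. Nothing at hand explains the direction of this step.

Still open, from the compounds shown here alone, is how a carboxylic acid or an amine in place of the nitrile would read on this chain. Also open, going by these compounds, is whether the step keeps its direction on the chains of compound 1 and compound 2.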